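This account rests on a few compounds, and the source may have more. Where it says the series, first, only, none or still open, it means among the compounds named here.

Compound 2, `CCCCCCCCCCCOC(=O)CCC(=O)N1CCN(CCCOc2cc3c(Nc4ccc(F)c(Cl)c4)ncnc3cc2OC)CC1`, stands at the lower of the two numbers seen so far: in a functional assay on A549 cells (Homo sapiens) for cytotoxicity, read by MTT assay, with a stated time of 24 h, tested at 60 uM (a lower number here means a stronger effect, a higher number a weaker effect of the compound at the concentration tested), compound 2 gives 3.9%. Among the measured compounds shown here, the only other measured compound, compound 1, `CCCCOC(=O)CCC(=O)N1CCN(CCCOc2cc3c(Nc4ccc(F)c(Cl)c4)ncnc3cc2OC)CC1`, gives 64.1% in this assay, and the step between them, heptyl in place of hydrogen on a saturated chain carbon, was a number 60.2 percentage points lower from compound 1 to compound 2 (beyond the scatter). Compound 3, `CCCCCCCCCCCCCCOC(=O)CCC(=O)N1CCN(CCCOc2cc3c(Nc4ccc(F)c(Cl)c4)ncnc3cc2OC)CC1`, is not yet measured; it differs from compound 2 by propyl in place of hydrogen on a saturated chain carbon, ten or more bonds along the chain from an oxygen next to a carbonyl group. For the measured compounds named here, the one measured step bearing on this change was large and downward, but compound 2 already sits near the bottom of the scale, so a further lengthening has little room to move the number down, and nothing measured speaks for a rise. The expected step is therefore none beyond the scatter, a number 0.1 percentage points higher from compound 2 to compound 3 (within the scatter). Compound 3 is thus expected to give 4%, with a range from 0% to 15%.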

Compound 3, a percentage reported as activity, at one concentration (the size of the read-out at that concentration, not a potency): 84.9%
Compound 3: the middle estimate sits 80.9 percentage points below what was measured, outside the stated range (above it).
By their numbers in this assay, from the lowest: compound 2; then compound 1; then compound 3.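

In this assay, lengthening the chain at this position does not push the number in one direction: the drop seen on adding heptyl turns into a rise, a number 81 percentage points higher from compound 2 to compound 3 (beyond the scatter), when propyl is added further out. The longest chain even ends on the weaker side of the shortest one, a number 20.8 percentage points higher from compound 1 to compound 3 (beyond the scatter), so among these three chains the strongest effect lies at the intermediate length rather than at either end. Nothing shown here gives a reason for this reversal.

Chains of lengths between those of the three compounds would show where the rise begins and whether it is abrupt or gradual. From the compounds shown here alone, it also remains open whether a longer chain stays as weak, and how an amine or a carboxylic acid at the chain end would read.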